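The source may report more compounds than this note shows. Statements on the series, on what has been measured and on what is new or still open speak of the compounds shown alone.

Measured compounds in an assay on cells for inhibition of HSP60/HSP10 (Homo sapiens), with a stated time of 60 min; on this read-out lower numbers stand for stronger inhibition and higher numbers for weaker inhibition:
- compound 1 `O=S(=O)(Nc1ccc2oc(-c3ccccc3)nc2c1)c1ccc(O)cc1` gives 88000 nM
- compound 2 `COc1cccc(S(=O)(=O)Nc2ccc(-c3nc4ccccc4o3)cc2)c1` gives 80000 nM
- compound 3 `O=S(=O)(Nc1ccc(-c2nc3cc(NS(=O)(=O)c4ccc(O)cc4)ccc3o2)cc1)c1ccc(O)cc1` gives 14000 nM

Compound 1 carries the highest number of the three. Its nearest neighbour on this read-out is compound 2, whose number sits within the scatter of compound 1, so no order can be drawn between them. Going by the values given here, compound 3 lies furthest away: the only step among the measured compounds that differs in one place, a 6.3-fold lower number from compound 1 to compound 3 (0.80 log units; beyond the scatter), adds a second ((4-hydroxyphenyl)sulfonyl)amino group to the shared core and lowers the number by a modest, but real, amount.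

Compound 4 `COc1ccccc1S(=O)(=O)Nc1ccc2oc(-c3ccccc3)nc2c1` is not yet measured. It differs from compound 1 in one place: 2-methoxyphenyl in place of 4-hydroxyphenyl on a sulfonyl sulfur. Among the compounds with values here, no measured step alters the aryl group on the sulfonyl sulfur, so the single step known in this assay does not bear on this change directly. Compound 2, which carries a methoxyphenyl sulfonamide on a differently arranged core, sits within the scatter of compound 1, and that is the only hint available. The step from compound 1 to compound 4 in this assay is therefore expected to be none beyond the scatter, a 1.0-fold higher number from compound 1 to compound 4 (0.01 log units; within the scatter). Compound 4 is estimated at 90000 nM, with a range from 40000 nM to 200000 nM.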

Compound 4, half-maximal inhibitory concentration: > 100000 nM
Compound 4: no number, only a limit (the forecaster's own chance of this, stated with the estimate: 25%); at least 1.1-fold (0.04 log units) between middle value and limit.
By their numbers in this assay, from the lowest: compound 3; then compounds 2 and 1 (each within the scatter of the next). At a limit, above all of these: compound 4.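

In this assay compound 4 gives > 100000 nM, which is a limit and not a number. Going by these compounds alone, this is the first reading on the aryl group on the sulfonyl sulfur: 2-methoxyphenyl in place of 4-hydroxyphenyl gives an at least 1.1-fold higher number from compound 1 to compound 4 (0.05 log units; that floor lies within the scatter), so the change brings no lowering of the number, though how far it raises it stays unknown. The step has only a floor because the reading stands at the limit of the assay: the limit of > 100000 nM in this assay, at which 1 of the 4 values shown sits.

The change alters both the group on the aryl ring and its place, and only 4-methoxyphenyl or 2-hydroxyphenyl on the sulfonyl sulfur would separate the two. Also open, going by these compounds, are an amine or a carboxylic acid on that aryl ring, and whether 2-methoxyphenyl would behave the same on the core of compound 3.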